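This account rests on a few compounds, and the source may have more. Where it says the series, first, only, none or still open, it means among the compounds named here.

Measured in a functional assay on HCT-116 cells (Homo sapiens), read by MTT assay, with a stated time of 72 h; a higher number here means a weaker inhibitor, a lower number a stronger inhibitor:
compound 1, `O=c1[nH]cnc2c1c(-c1ccoc1)cn2[C@@H]1O[C@H](CO)[C@@H](O)[C@H]1O`: 10300 nM
compound 2, `CN(C)c1ncnc2c1c(-c1ccsc1)cn2[C@@H]1O[C@H](CO)[C@@H](O)[C@H]1O`: limit, > 20000 nM
compound 3, `Cc1ncnc2c1c(I)cn2[C@@H]1O[C@H](CO)[C@@H](O)[C@H]1O`: 4720 nM

Compound 1 gives 10300 nM in this assay and compound 3 gives 4720 nM. Within the data shown here, for compound 2 this assay reports only a limit, > 20000 nM, which is a boundary of the assay and not a number; it is the one value of the three that sits there (the limit of > 20000 nM in this assay, at which 1 of the 3 values shown sits). Compound 2 thus stands at the weak end of the numbers shown, without a value of its own.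

Compound 4, `CN(C)c1ncnc2c1c(-c1ccoc1)cn2[C@@H]1O[C@H](CO)[C@@H](O)[C@H]1O`, differs from compound 2 by furan-3-yl in place of thiophen-3-yl on an aromatic carbon. Among the measured compounds shown here, no pair of measured compounds differs in one place only, so the size of this change is not known from the set. Compound 1 carries the same furan-3-yl group with a different group on the other ring and gives 10300 nM, a weak value too. The expected step is a number no higher from compound 2 to compound 4 (the limit leaves the size open), no larger than the scatter, in either direction. Compound 4 is expected at about 20000 nM, between 8000 nM and 45000 nM, with a fair chance that this assay again reports only a limit.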

Compound 4, half-maximal inhibitory concentration: > 20000 nM
Compound 4: only a limit was reported; the forecaster's own chance of this, stated with the estimate: 55%; the middle value lies on the limit itself.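

Compound 2 and compound 4 are both reported only as limits in this assay, so no step can be read for furan-3-yl in place of thiophen-3-yl: the limit of > 20000 nM in this assay, at which 2 of the 4 values shown sit.

The compounds shown leave open how weak either compound really is, and whether this exchange changes the read-out at all.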